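A few compounds are considered here, and "the series" means these few. Any claim that something is new, unique, unknown or untested is made for them only; others in the source may bear on it.

Measured compounds:
compound 1, `CCCS(=O)(=O)N1CCC(CNC(=O)c2ccc(Cl)cc2Cl)(C(=O)N2CC(N)C2)CC1`, 109 nM
compound 2, `CCCS(=O)(=O)N1CCC(CNC(=O)c2c(F)cccc2F)(C(=O)N2CCOCC2)CC1`, 131 nM

In an assay on isolated protein for inhibition of sodium- and chloride-dependent glycine transporter 1 (Homo sapiens) (a lower number here means a stronger inhibitor, a higher number a weaker inhibitor), compound 1 gives 109 nM. In this assay compound 2 gives 131 nM. Compound 2 stands alongside compound 1: the gap between the two values lies within the usual scatter, so neither compound can be called the stronger inhibitor on these numbers.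

Compound 3, `CCCS(=O)(=O)N1CCC(CNC(=O)c2ccccc2OC(F)(F)F)(C(=O)N2CCOCC2)CC1`, has not yet been measured in this assay. It differs from compound 2 at one place only:

2-(trifluoromethoxy)phenyl in place of 2,6-difluorophenyl on a carbonyl carbon

The incoming 2-(trifluoromethoxy)phenyl brings one hydrogen-bond acceptor where the 2,6-difluorophenyl had none, and it is the larger group. Among the measured compounds shown here, no measured pair shows what such a change does here, so there is no step to lean on. Compound 3 is expected to stay close to compound 2, with the step of a 1.3-fold higher number from compound 2 to compound 3 (0.11 log units; within the scatter) expected to fall within the scatter or to lean slightly toward a weaker inhibitor. Compound 3 is therefore estimated at 170 nM, with a range from 60 nM to 500 nM.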

Compound 3, half-maximal inhibitory concentration in the sodium- and chloride-dependent glycine transporter 1 assay: 88.4 nM
Estimate against measurement, compound 3: 1.9-fold (0.28 log units) above; the range from low to high includes it.
By their numbers in the sodium- and chloride-dependent glycine transporter 1 assay, from the lowest: compounds 3, 1 and 2 (each within the scatter of the next).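

In the sodium- and chloride-dependent glycine transporter 1 assay the change at this place, on a carbonyl carbon, gives (a 1.5-fold lower number from compound 2 to compound 3 (0.17 log units; within the scatter)), so the larger 2-(trifluoromethoxy)phenyl, with its hydrogen-bond acceptor, stands level with 2,6-difluorophenyl. In a physicochemical assay for solubility (on this read-out higher numbers stand for higher solubility and lower numbers for lower solubility), compound 2 gives 10000 ug/mL and compound 3 gives 10000 ug/mL as the same printed value, so this change also leaves that read-out level. Nothing at hand explains why either read-out stays level.

The compounds shown leave open whether this place would stay as level with a group of another kind, such as a phenyl ring carrying an amine or a carboxylic acid. They also leave open whether a longer chain in place of the propyl on the sulfonyl would hold these numbers.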